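The source may report more compounds than this note shows. Statements on the series, on what has been measured and on what is new or still open speak of the compounds shown alone.

Measured compounds:
Compound 1 `CCOC(=O)c1cccc(-c2ccc(N(C)C)cc2)c1` gives 87% in an assay on COS-7 cells for inhibition of patatin-like phospholipase domain-containing protein 2 (Mus musculus), tested at 200 uM; on this read-out lower numbers stand for less inhibition and higher numbers for more inhibition at the one concentration tested (going by the name of the read-out).
Compound 2 `CCOc1ccc(-c2cccc(C(=O)O)c2)cc1` gives 23% in this assay.
Compound 3 `CCOc1ccc(-c2cccc([N+](=O)[O-])c2)cc1` gives 35% in this assay.

Compound 3 stands second highest of the three numbers in this assay; its nearest neighbour is compound 2, and the one step measured between two of these compounds, a number 12 percentage points higher from compound 2 to compound 3 (beyond the scatter), is a modest rise. Compound 1 lies far above both of them.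

The step to compound 4 `CN(C)c1ccc(-c2cccc([N+](=O)[O-])c2)cc1` is dimethylamino in place of ethoxy on an aromatic carbon. Among the compounds with values here, no measured step covers this exact change. Compound 1 and compound 2 differ from each other in two places at once, one of them being this same exchange of ethoxy for dimethylamino, and their two values show the dimethylamino-bearing compound 1 far higher than the ethoxy-bearing compound 2. That comparison is the only hint at hand, and it is confounded by the second difference, so the size of the step in this assay is uncertain, though the direction is expected to be upward.

Compound 4 is therefore expected to give 55% in this assay, within 30% to 80%, an expected step of a number 20 percentage points higher from compound 3 to compound 4 (beyond the scatter).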

Compound 4, a percentage reported as inhibition, at one concentration (the size of the read-out at that concentration, not a potency): 21%
Beside the measured number, compound 4's estimate is 34 percentage points above it, and the stated range ends above it.
By their numbers in this assay, from the lowest: compounds 4 and 2 (each within the scatter of the next); then compound 3; then compound 1.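

In this assay, the exchange of ethoxy for dimethylamino now has a measured size on a shared core, and it runs downward: a number 14 percentage points lower from compound 3 to compound 4 (beyond the scatter). With dimethylamino held fixed, nitro in place of ethoxycarbonyl gives a number 66 percentage points lower from compound 1 to compound 4 (beyond the scatter), the largest step seen so far, so the high number of compound 1 cannot be credited to dimethylamino alone. Nothing at hand gives a measured reason for either step.

The compounds shown leave open whether dimethylamino in place of ethoxy would also lower the number on a core that carries ethoxycarbonyl. They also leave open how much of the height depends on the ester itself, which a methyl ester, an amide or a nitrile at that place would help to tell.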